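A few compounds are considered here, and "the series" means these few. Any claim that something is new, unique, unknown or untested is made for them only; others in the source may bear on it.

Compound 1, `COc1ccc(SCc2ccc(/C=C/C(=O)Nc3ccccc3N)cc2)cc1OC`, gives 65.5% in a functional assay on A549 cells (Homo sapiens) for inhibition, read by CCK-8 assay, with a stated time of 72 h, tested at 2 uM; on this read-out lower numbers stand for less inhibition of growth and higher numbers for more inhibition of growth at the one concentration tested.
Compound 2, `Nc1ccccc1NC(=O)c1ccc(CSc2ccc(Br)cc2)cc1`, gives 33.2% in this assay.
Compound 3, `CC(C)(C)c1ccc(SCc2ccc(C(=O)Nc3ccccc3N)cc2)cc1`, gives 38.6% in this assay.

Among these three, compound 1 stands highest in this assay. Its nearest neighbour is compound 3, whose value is lower by a margin beyond the scatter, and the furthest is compound 2, lower still. Compounds 2 and 3 differ only in the group on the distal aromatic ring, and that exchange gave a number 5.4 percentage points higher from compound 2 to compound 3 (within the scatter), a step within the scatter.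

The account now follows compound 1 to compound 4, `Nc1ccccc1NC(=O)/C=C/c1ccc(CSc2ccc(C(F)(F)F)cn2)cc1`. The change is 5-(trifluoromethyl)pyridin-2-yl in place of 3,4-dimethoxyphenyl on a sulfur. For the measured compounds named here, the only measured step that bears on it is the one from compound 2 to compound 3, which also alters the ring attached to the sulfur and which stayed within the scatter. Going by the values given here, no measured pair exchanges a carbon-only ring for a ring holding a nitrogen, so that part of the change has no precedent here. On this basis compound 4 is expected to stay close to compound 1, with a number 5.5 percentage points lower from compound 1 to compound 4 (within the scatter) estimated as a step of no clear direction beyond the scatter. Compound 4 is therefore estimated at 60%, within a range from 40% to 76%.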

Compound 4, percent growth inhibition at one concentration: 51.7%
Estimate against measurement, compound 4: 8.3 percentage points above, and the stated range covers the measured number.
By their numbers in this assay, from the lowest: compounds 2 and 3 (each within the scatter of the next); then compound 4; then compound 1.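

In this assay the exchange of 3,4-dimethoxyphenyl for 5-(trifluoromethyl)pyridin-2-yl on the sulfur gave a number 13.8 percentage points lower from compound 1 to compound 4 (beyond the scatter) and so showed that the group on this sulfur can move the number beyond the scatter, something the exchange of bromo for tert-butyl, with a number 5.4 percentage points higher from compound 2 to compound 3 (within the scatter) on a different core, did not show. The step is modest, and compound 4 still gives 51.7% in this read-out, so a ring with one hetero atom and a trifluoromethyl group on the sulfur keeps a good part of the growth inhibition seen with the core of compound 1 at the one concentration tested. Nothing at hand gives a reason for this step.

The compounds shown leave open whether the ring nitrogen or the trifluoromethyl group carries the step, as the two enter together and the methoxy groups leave at the same time, so that a plain pyridin-2-yl or a 4-methoxyphenyl on the sulfur would be needed to separate these parts. Also open, from the compounds shown here alone, is how this read-out would respond to an amine or a carboxylic acid on the ring attached to the sulfur.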